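A few compounds are considered here, and "the series" means these few. Any claim that something is new, unique, unknown or untested is made for them only; others in the source may bear on it.

Working notes on the indolecarbohydrazide series. For the measured compounds named here, in a functional assay on MDA-MB-231 cells (Homo sapiens) for cytotoxicity (on this read-out lower numbers stand for stronger inhibition and higher numbers for weaker inhibition), compound 1 `O=C(N/N=C\c1cn(Cc2ccc(Cl)cc2)c2cc(F)ccc12)c1c[nH]c2ccccc12` gives 5300 nM, the second highest of the three numbers so far. Compound 3 `O=C(N/N=C\c1cn(Cc2ccc(Cl)cc2)c2cc(F)ccc12)c1c[nH]c2ccc(Br)cc12` gives 5100 nM, and the step of a 1.0-fold lower number from compound 1 to compound 3 (0.02 log units; within the scatter). Compound 2 `COc1ccc(Cn2cc(/C=N\NC(=O)c3c[nH]c4ccccc34)c3ccc(F)cc32)cc1` gives 71200 nM; the step of a 13-fold higher number from compound 1 to compound 2 (1.13 log units; beyond the scatter). Compound 4 `O=C(N/N=C\c1cn(Cc2ccc(Cl)cc2)c2ccccc12)c1c[nH]c2ccccc12` differs from compound 1 by hydrogen in place of fluoro on an aromatic carbon. Neither measured step touches that fluoro: the change to compound 3 sits on the hydrazide-side indole and left the number unmoved, while the large change to compound 2 sits on the benzyl group. Going by the values given here, no step therefore bears directly on compound 4, and the default expectation is no movement beyond the scatter, as in the step to compound 3. Compound 4 is estimated at 6000 nM, between 2500 nM and 15000 nM, which is an expected step of a 1.1-fold higher number from compound 1 to compound 4 (0.05 log units; within the scatter).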

Compound 4, half-maximal inhibitory concentration: 66400 nM
Beside the measured number, compound 4's estimate is 11-fold (1.04 log units) below it; the whole stated range lies below it.
By their numbers in this assay, from the lowest: compounds 3 and 1 (each within the scatter of the next); then compounds 4 and 2 (each within the scatter of the next).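

The fluoro position is not silent: replacing fluoro with hydrogen gives a 13-fold higher number from compound 1 to compound 4 (1.10 log units; beyond the scatter) in this assay, although only one heavy atom leaves and no ring, hydrogen-bond donor, hydrogen-bond acceptor or net charge changes. For the compounds shown here, this is the first measured step showing that a change at this position on the shared core can move the number. Nothing at hand accounts for the size of this step.

Only fluoro and hydrogen are shown at this position, so it remains open whether the number depends on fluoro itself or would also hold with a nitrile or an amine there.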